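Dimethylphenyl Ether Variant: Expected Solubility

The source may report more compounds than this note shows. Statements on the series, on what has been measured and on what is new or still open speak of the compounds shown alone.

In a physicochemical assay for solubility, read by HPLC, measured as thermodynamic solubility, with a stated time of 4 h, at pH 6.8 (on this read-out lower numbers stand for lower solubility and higher numbers for higher solubility), compound 2 `Cc1ccc(Oc2ccc3nc(COc4cccc(C(=O)O)c4)n(C)c3n2)cc1F` gives 5.2 ug/mL, the lowest of the two numbers shown, while compound 1 `Cn1c(COc2cccc(C(=O)O)c2)nc2ccc(Oc3ccc(F)cc3)nc21` gives 11 ug/mL. For the measured compounds named here, the one measured step that bears on the next change is a 2.1-fold lower number from compound 1 to compound 2 (0.33 log units; beyond the scatter). Compound 3 `Cc1cc(C)cc(Oc2ccc3nc(COc4cccc(C(=O)O)c4)n(C)c3n2)c1` differs from compound 2 by 3,5-dimethylphenyl in place of 3-fluoro-4-methylphenyl on an oxygen on an aromatic ring. Going by the values given here, that earlier step was modest, and no measured pair shows this exact exchange. The estimated step of a 1.3-fold lower number from compound 2 to compound 3 (0.11 log units; within the scatter) is therefore small, a slight fall in solubility that may stay within the scatter. Compound 3 is expected to give 4 ug/mL, with a range from 1.5 ug/mL to 10 ug/mL.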

Compound 3, solubility: 0.5 ug/mL
The estimate for compound 3 lay 8.0-fold (0.90 log units) above the measured number; measured number below the stated range.
By their numbers in this assay, from the lowest: compound 3; then compound 2; then compound 1.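

In this assay, the aryl group on the oxygen proves much more sensitive to change than the earlier pair showed: the exchange gives a 10-fold lower number from compound 2 to compound 3 (1.02 log units; beyond the scatter), although the heavy-atom count and the carbon-only aromatic ring stay the same. Set against the 4-fluorophenyl group, the 3,5-dimethylphenyl group gives a 22-fold lower number from compound 1 to compound 3 (1.34 log units; beyond the scatter), also a large step. Nothing shown here accounts for these falls.

Still open, going by these compounds, is whether the loss of fluorine or the new arrangement of methyl groups matters more. Also open, on these data alone, is how an amine or a carboxylic acid on this aryl ring would read in this assay.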